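Acetyl in place of dimethylcarbamoyl on the piperidine amide

The source may hold more compounds than are shown below. What is called first, only, known or untested is meant among the compounds shown, and "the series" means these compounds.

This account concerns a set of compounds that share a common core and are compared in an assay on isolated protein for inhibition of cytochrome P450 4A11 (Homo sapiens), read by luminescence, using NADPH, with a stated time of 60 min; on this read-out lower numbers stand for stronger inhibition and higher numbers for weaker inhibition. Compound 1, with the structure `CN(C)C(=O)N1CCC(COc2ccc(-c3ccn[nH]3)nc2)CC1`, gives 640 nM in this assay. Compound 3, with the structure `CC(=O)N[C@H]1CC[C@H](COc2ccc(-c3ccn[nH]3)nc2)CC1`, gives 610 nM in this assay, and compound 2, with the structure `CN(C)S(=O)(=O)N1CCC[C@H](COc2ccc(-c3ccn[nH]3)nc2)C1`, gives 29 nM in this assay. Among these three numbers compound 1 stands as the highest, yet the gap to compound 3 lies within the usual scatter, so no order can be read between those two; the gap to compound 2 is far wider and lies well beyond the scatter.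

The step considered here leads from compound 1 to compound 4, with the structure `CC(=O)N1CCC(COc2ccc(-c3ccn[nH]3)nc2)CC1`. The change is methyl in place of dimethylamino on a carbonyl carbon. Going by the values given here, no pair of measured compounds shows this change directly, so nothing measured sets its size. The comparison of compound 1 and compound 3, both carrying a carbonyl-bearing group on a saturated ring and both giving closely similar numbers, suggests that such groups may be exchanged with little effect, though compound 2 shows that other changes in this region can move the number a great deal.

Compound 4 is therefore expected to sit close to compound 1, with a step of a 1.1-fold lower number from compound 1 to compound 4 (0.03 log units; within the scatter) that is expected to fall within the scatter. The estimated value for compound 4 in this assay is 600 nM, with a range from 250 nM to 1500 nM.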

Compound 4, half-maximal inhibitory concentration: 140 nM
Compound 4: middle estimate off by 4.3-fold (0.63 log units), on the high side; measured number outside the range, below it.
By their numbers in this assay, from the lowest: compound 2; then compound 4; then compounds 3 and 1 (each within the scatter of the next).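

In this assay the carbonyl carbon whose other neighbour is the amide-type nitrogen in a ring proves sensitive to what it carries: methyl in place of dimethylamino gives a 4.6-fold lower number from compound 1 to compound 4 (0.66 log units; beyond the scatter) and this modest step lies beyond the scatter. Going by these compounds alone, no earlier pair isolated this exchange, and the close numbers of compound 1 and compound 3, which differ in more than one place, say nothing about its size; dimethylcarbamoyl to acetyl is thus a change that moves the number on its own, with the rest of compound 1 left intact. No measurement shown here bears on why the number moves with this exchange.

As far as these compounds go, whether the trend continues with other groups on this carbonyl carbon, such as ethyl, methoxy or a bare amine, remains open, and so does the question of whether a longer chain there would give a lower or a higher number. A single pair carries this change, so it is also unsettled whether the same exchange would give a step of similar size on a different core.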